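The source may report more compounds than this note shows. Statements on the series, on what has been measured and on what is new or still open speak of the compounds shown alone.

For the measured compounds named here, compound 1, with the structure `COC(=O)/C(=C\c1ccc(OC(=O)c2cccc(OC)c2)cc1)Sc1ccnc2cc(Cl)ccc12`, is the weaker of the two measured members of this pair. In a functional assay on HL-60 cells (Homo sapiens) for cytotoxicity, read by MTT assay, with a stated time of 24 h (on this read-out lower numbers stand for stronger inhibition and higher numbers for weaker inhibition), compound 1 gives 25500 nM, the highest of the two numbers recorded. Its nearest neighbour is compound 2, with the structure `COC(=O)/C(=C\c1ccc(OC(=O)c2cccc(OC)c2OC)cc1)Sc1ccnc2cc(Cl)ccc12`, which in this assay gives 13000 nM. Going by the values given here, the only measured step is a 2.0-fold lower number from compound 1 to compound 2 (0.29 log units; within the scatter), a methoxy in place of hydrogen on an aromatic carbon.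

Compound 3, with the structure `COC(=O)/C(=C\c1ccc(OC(=O)c2cc(OC)c(OC)c(OC)c2)cc1)Sc1ccnc2cc(Cl)ccc12`, has not yet been measured. It differs from compound 1 as follows: 3,4,5-trimethoxyphenyl in place of 3-methoxyphenyl on a carbonyl carbon. The step from compound 1 to compound 2 is the one that bears on this change, since it also adds methoxy groups to the same aromatic ring, and that step stayed within the scatter. Two further methoxy groups are added here, so a somewhat larger move in the same direction is plausible, but nothing in the data demands it. The step is therefore expected to be a 2.3-fold lower number from compound 1 to compound 3 (0.37 log units; beyond the scatter). For compound 3 in this assay the estimate is 11000 nM, within a range from 4000 nM to 30000 nM.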

Compound 3, half-maximal inhibitory concentration: 4240 nM
The estimate for compound 3 lay 2.6-fold (0.41 log units) above the measured number; low and high end bracket the measured number.
By their numbers in this assay, from the lowest: compound 3; then compounds 2 and 1 (each within the scatter of the next).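

In this assay, the aromatic group on this carbonyl carbon proves able to move the number beyond the scatter, which the earlier pair of compounds had not shown. Putting 3,4,5-trimethoxyphenyl in place of 3-methoxyphenyl gives a 6.0-fold lower number from compound 1 to compound 3 (0.78 log units; beyond the scatter), and putting it in place of 2,3-dimethoxyphenyl gives a 3.1-fold lower number from compound 2 to compound 3 (0.49 log units; beyond the scatter), so compound 3 has the lowest number of the three, with both of its steps printed as beyond the scatter. Nothing measured alongside these numbers bears on why the trimethoxy compound stands apart.

The compounds shown leave open whether all three methoxy groups are needed at this place, and how a 3,4,5-trihydroxyphenyl group or an aminophenyl group on the same carbonyl carbon would compare with the 3,4,5-trimethoxyphenyl group. They also leave open whether the number for compound 3 would hold with a carboxylic acid in place of the methyl ester, or with an amide in place of the ester linking the 3,4,5-trimethoxyphenyl carbonyl group to the rest of the molecule.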